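Terminal amine exchange on the shared core side chain

The source may report more compounds than this note shows. Statements on the series, on what has been measured and on what is new or still open speak of the compounds shown alone.

Among the measured compounds shown here, compound 2 `COc1cc2c(Nc3ccc(C#N)cc3)ncnc2cc1OCCCN1CCC(N2CCCCC2)CC1` is the only member of the set with a number in a functional assay on HepG2 cells (Homo sapiens) for antiproliferative activity, read by MTT assay, with a stated time of 72 h; on this read-out lower numbers stand for stronger inhibition and higher numbers for weaker inhibition; in this assay compound 2 gives 8840 nM. Compound 1 `COc1cc2c(Nc3ccc(C#N)cc3)ncnc2cc1OCCCN(C)C` reaches only the assay limit (the limit of > 100000 nM in this assay, at which 1 of the 2 values shown sits), giving > 100000 nM. For the measured compounds named here, the single measured step, an at least 11-fold lower number from compound 1 to compound 2 (1.05 log units; beyond the scatter), is large. Compound 3 `COc1cc2c(Nc3ccc(C#N)cc3)ncnc2cc1OCCCN1CCN(c2ccncc2)CC1` carries 4-(pyridin-4-yl)piperazin-1-yl in place of 4-(piperidin-1-yl)piperidin-1-yl on a saturated chain carbon, three bonds along the chain from an oxygen on an aromatic ring. Going by the values given here, no measured step covers this exchange; the only step shows a large terminal group lowering the number relative to dimethylamino, and compound 3 keeps a terminal group of matching size. The expected step is therefore a 1.7-fold higher number from compound 2 to compound 3 (0.23 log units; within the scatter), roughly within the scatter. Compound 3 is expected to give 15000 nM, between 4000 nM and 60000 nM.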

Compound 3, half-maximal inhibitory concentration: 12600 nM
Estimate against measurement, compound 3: 1.2-fold (0.08 log units) above; the range from low to high includes it.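

On the saturated chain carbon, three bonds along the chain from an oxygen on an aromatic ring, 4-(pyridin-4-yl)piperazin-1-yl and 4-(piperidin-1-yl)piperidin-1-yl cannot be told apart in this assay (a 1.4-fold higher number from compound 2 to compound 3 (0.15 log units; within the scatter)). The separation from dimethylamino is therefore not confined to one large terminal group, as a second one also gives an at least 7.9-fold lower number from compound 1 to compound 3 (0.89 log units; beyond the scatter) on this chain. That step rests on a limit of compound 1, not on a number: the limit of > 100000 nM in this assay, at which 1 of the 3 values shown sits.

Open, on these data alone, is where a single-ring terminal amine such as morpholine or piperidine would fall. As far as these compounds go, a longer chain carrying these terminal groups also remains open.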